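From furan-2-yl to pyridin-4-yl at an assay limit

The source may report more compounds than this note shows. Statements on the series, on what has been measured and on what is new or still open speak of the compounds shown alone.

Measured so far in an ADME assay for permeability, using PAMPA, with a stated time of 4 h, tested at 10 uM; on this read-out lower numbers stand for lower permeability and higher numbers for higher permeability
Compound 1 (`COc1ccc(-c2cnc(NC(=O)CCCCN3CCCN(C(C)=O)CC3)[nH]2)cc1`) gives (> 10 10^-6 cm/s), a limit
Compound 2 (`O=C(CCCCN1CCCCC1)Nc1cc(-c2ccco2)n[nH]1`) gives (> 10 10^-6 cm/s), a limit

In this assay compound 2 gives only a limit and not a number (> 10 10^-6 cm/s). For the measured compounds named here, the data so far amount to (the limit of > 10 10^-6 cm/s in this assay, at which 2 of the 2 values shown sit), so no measured step shows how far a structural change can move this read-out.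

Compound 3 (`O=C(CCCCN1CCCCC1)Nc1cc(-c2ccncc2)n[nH]1`) has pyridin-4-yl in place of furan-2-yl on an aromatic carbon. The rest of compound 2 stays the same.

With no measured swap to guide the expectation, the starting point is compound 2 at (> 10 10^-6 cm/s), which is a limit. A small downward move is expected, of a size that may not stand out from the usual scatter of repeated measurements. The estimated change is (an at least 1.2-fold lower number from compound 2 to compound 3 (0.09 log units; that floor lies within the scatter)), and this direction is tentative. The result could also turn out to be a limit again. The estimated value for compound 3 is (8 10^-6 cm/s), with an expected range from (3 10^-6 cm/s) to (20 10^-6 cm/s).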

Compound 3, apparent permeability: 2 10^-6 cm/s
Compound 3: middle estimate off by 4.0-fold (0.60 log units), on the high side, and the stated range ends above it.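

In this assay, this place, an aromatic carbon of a five-membered aromatic ring with 2 nitrogen, proves able to move the read-out: pyridin-4-yl in place of furan-2-yl gives an at least 5.0-fold lower number from compound 2 to compound 3 (0.69 log units; beyond the scatter). Compound 2 gives only a limit, so this step is a floor and the true drop could be larger, while the rest of compound 2 stays the same in compound 3. Compound 3 is also the first compound here with a real number, which gives later changes a measured value to be compared with, unlike the earlier picture: the limit of > 10 10^-6 cm/s in this assay, at which 2 of the 3 values shown sit.

The swap changes the ring size and also replaces the ring oxygen with a ring nitrogen, so this single step cannot tell which of the two differences counts. On these data alone, a phenyl ring would share the six-membered size without the ring nitrogen, and pyridin-3-yl would keep that nitrogen in another place, so both would help to separate these effects, and it also remains open whether the same swap would lower the number on a compound with a different side chain.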